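Methoxy in Place of Hydrogen in Compound 3

The compounds below may be only part of what the source reports. "The series", "measured", "known", "first", "only" and "open" are said of these compounds alone.

In an in vivo ADME assay on the whole organism for pharmacokinetics, with Canis familiaris (Canis lupus familiaris) as the target, at a dose of 0.25 mg/kg by the intravenous route (on this read-out higher numbers stand for fast clearance and lower numbers for slow clearance), compound 1 (`O=c1[nH]c2ccc(-c3cn[nH]c3)cc2cc1-c1cc2cc(CN3CCC(F)CC3)ccc2[nH]1`) gives 22 mL/min/kg while compound 2 (`CC(=O)N1CCN(Cc2ccc3[nH]c(-c4cc5cc(-c6cn[nH]c6)ccc5[nH]c4=O)cc3c2)CC1`) gives 27 mL/min/kg as its clearance. Among the measured compounds shown here, compound 2 therefore stands within the usual scatter of compound 1, the only other measured compound. Compound 3 (`COCC(=O)N1CCN(Cc2ccc3[nH]c(-c4cc5cc(-c6cn[nH]c6)ccc5[nH]c4=O)cc3c2)CC1`) differs from compound 2 by methoxy in place of hydrogen on a saturated chain carbon bound to a carbonyl carbon and in words this is methoxy in place of hydrogen on a saturated chain carbon bound to a carbonyl carbon, so that acetyl becomes (methoxymethyl)carbonyl. For the measured compounds named here, only one measured step bears on this change. It is a 1.2-fold higher number from compound 1 to compound 2 (0.09 log units; within the scatter) and it exchanges the whole 4-fluoropiperidin-1-yl group for 4-acetylpiperazin-1-yl while staying within the scatter. Going by the values given here, no measured pair tests methoxy itself, so this evidence is indirect. The estimated 1.0-fold lower number from compound 2 to compound 3 (0.02 log units; within the scatter) in this assay is expected to stay within the scatter, with neither direction firmly favoured. Compound 3 is expected at 26 mL/min/kg with an estimated range from 14 mL/min/kg to 45 mL/min/kg for its clearance.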

Compound 3, clearance: 2.3 mL/min/kg
Beside the measured number, compound 3's estimate is 11-fold (1.05 log units) above it; the measured number lies below the stated range.
By their numbers in this assay, from the lowest: compound 3; then compounds 1 and 2 (each within the scatter of the next).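

In this assay, among the compounds shown here, the saturated chain carbon bound to a carbonyl carbon proved far more sensitive than the earlier compounds could suggest: methoxy in place of hydrogen there gives a 12-fold lower number from compound 2 to compound 3 (1.07 log units; beyond the scatter) while the earlier exchange of 4-fluoropiperidin-1-yl for 4-acetylpiperazin-1-yl had stayed within the scatter. Read against the fluorinated compound, 4-((methoxymethyl)carbonyl)piperazin-1-yl in place of 4-fluoropiperidin-1-yl gives a 9.6-fold lower number from compound 1 to compound 3 (0.98 log units; beyond the scatter) so the clearance moved beyond the scatter only once the methoxy was present on the acetyl group. Nothing among the data available accounts for this drop in clearance.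

From the compounds shown here alone, whether the drop belongs to methoxy itself remains open, since ethoxy, hydroxyl, an amine such as dimethylamino, or a longer chain ending in methoxy on the same saturated chain carbon would show how specific the change is. Going by these compounds, it is also open whether a step of this size would hold in species other than the dog, as these three compounds offer only this single read-out of clearance.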